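This account rests on a few compounds, and the source may have more. Where it says the series, first, only, none or still open, it means among the compounds named here.

Measured so far: compound 1 `CC(C)(CNC(=O)c1ccccc1)CC1=C(O)C(=O)c2ccccc2C1=O` with 50500 nM; compound 2 `COC1=C(CC(C)(C)CNC(=O)c2ccccc2)C(=O)c2ccccc2C1=O` with 12300 nM; compound 3 `COc1ccc(O)c(C(=O)NCC(C)(C)CC2=C(O)C(=O)c3ccccc3C2=O)c1` with 31100 nM. All three were tested in an ADME assay on Vero cells (Chlorocebus sabaeus) for cytotoxicity, read by fluorescence, with a stated time of 4 days; a lower number here means a stronger inhibitor, a higher number a weaker inhibitor.

Compound 2 differs from compound 1 by methyl in place of hydrogen on an oxygen on an unsaturated carbon, and that change gave a 4.1-fold lower number from compound 1 to compound 2 (0.61 log units; beyond the scatter). Compound 3 differs from compound 1 by 2-hydroxy-5-methoxyphenyl in place of phenyl on a carbonyl carbon, which gave a 1.6-fold lower number from compound 1 to compound 3 (0.21 log units; within the scatter). Compound 4 `COc1ccc(OC)c(C(=O)NCC(C)(C)CC2=C(O)C(=O)c3ccccc3C2=O)c1` has not yet been measured; it differs from compound 3 by methyl in place of hydrogen on an oxygen on an aromatic ring. Within the data shown here, this is the same kind of change as the one from compound 1 to compound 2, but not the same: there the methyl entered on an oxygen on an unsaturated carbon whose other neighbours are a double-bonded ring carbon, whereas in compound 4 it enters on an oxygen on an aromatic ring whose other neighbours are aromatic carbon. Because the earlier step of a 4.1-fold lower number from compound 1 to compound 2 (0.61 log units; beyond the scatter) was made at a different place, for compound 4 a smaller step is expected, a 1.6-fold lower number from compound 3 to compound 4 (0.19 log units; within the scatter). Compound 4 is therefore estimated at 20000 nM, between 8000 nM and 50000 nM.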

Compound 4, half-maximal inhibitory concentration: 89100 nM
Beside the measured number, compound 4's estimate is 4.5-fold (0.65 log units) below it; the measured number lies above the stated range.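

In this assay, adding a methyl on an oxygen did not carry over from one core to the other, as the two steps point in opposite directions: the same change on two cores in this assay, a 4.1-fold lower number (0.61 log units; beyond the scatter) from compound 1 to compound 2 and a 2.9-fold higher number (0.46 log units; beyond the scatter) from compound 3 to compound 4, 12-fold (1.07 log units) apart, beyond the scatter of two such steps. The new step reads a 2.9-fold higher number from compound 3 to compound 4 (0.46 log units; beyond the scatter) on an oxygen on an aromatic ring, and 2,5-dimethoxyphenyl in place of phenyl on a carbonyl carbon gives a 1.8-fold higher number from compound 1 to compound 4 (0.25 log units; within the scatter) overall. So a step measured at one place cannot simply be transferred to the other, but with a single pair at each place, this does not show why the steps differ or how the change would behave on further cores.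

The compounds shown leave open what a longer chain such as ethyl on the same oxygen would do. They also leave open the effect of an amine in place of the hydroxy.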